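The compounds below may be only part of what the source reports. "The series", "measured", "known", "first", "only" and "open" are said of these compounds alone.

Values from a functional assay on A549 cells (Homo sapiens) for inhibition, read by MTT assay, with a stated time of 48 h (a higher number here means a weaker inhibitor, a lower number a stronger inhibitor), are these:
- compound 1 `COc1ccc(C(c2c[nH]c3ccc(Br)cc23)c2c[nH]c3ccc(Br)cc23)cc1` gives 10000 nM
- compound 2 `CN(C)c1ccc(C(c2c[nH]c3ccc(Br)cc23)c2c[nH]c3ccc(Br)cc23)cc1` gives 25000 nM

Compound 2 holds the higher of the two numbers, with 25000 nM as its value. Compound 3 `O=[N+]([O-])c1ccc(C(c2c[nH]c3ccc(Br)cc23)c2c[nH]c3ccc(Br)cc23)cc1` has nitro in place of dimethylamino on an aromatic carbon. For the measured compounds named here, one measured step bears on this place, a modest one that brought in dimethylamino in place of methoxy: a 2.5-fold higher number from compound 1 to compound 2 (0.40 log units; beyond the scatter). Going by the values given here, no measured compound carries nitro, so the size is uncertain, but a similarly modest move toward a lower number is expected, namely a 2.1-fold lower number from compound 2 to compound 3 (0.32 log units; beyond the scatter) as an estimate. For compound 3 the estimated value is 12000 nM, with an expected range from 4000 nM to 35000 nM.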

Compound 3, half-maximal inhibitory concentration: 5500 nM
For compound 3 the middle estimate is 2.2-fold (0.34 log units) above the measured one, and the stated range covers the measured number.
By their numbers in this assay, from the lowest: compounds 3 and 1 (each within the scatter of the next); then compound 2.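

Replacing dimethylamino with nitro on this aromatic carbon, para to a large group, gives a clear change (a 4.5-fold lower number from compound 2 to compound 3 (0.66 log units; beyond the scatter)), so dimethylamino is the group that stands apart from the other two here. Nitro and methoxy cannot be told apart (a 1.8-fold lower number from compound 1 to compound 3 (0.26 log units; within the scatter)), as this step lies within the scatter. Nothing available gives a reason for these results. As far as these compounds go, it remains open whether a primary amine, a carboxylic acid or a fluorine atom at this position would match nitro and methoxy or differ from them.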